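Removing the Ethyl Group from an Anilide Oxabicycle

This account rests on a few compounds, and the source may have more. Where it says the series, first, only, none or still open, it means among the compounds named here.

Compound 1 `CCc1ccccc1NC(=O)C1C(C(=O)O)[C@@H]2CC[C@H]1O2` was tested in an ADME assay on MCF7 cells (Homo sapiens) for cytotoxicity, read by MTT assay, with a stated time of 72 h (a higher number here means a weaker inhibitor of growth, a lower number a stronger inhibitor of growth), and gave 10000 nM. Compound 2 `CCOC(=O)c1cn[nH]c1NC(=O)C1C(C(=O)O)[C@@H]2CC[C@H]1O2` gave 10000 nM in this assay, so compound 1 stands level with compound 2 within the scatter; neither can be called the stronger. Compound 3 `O=C(O)C1C(C(=O)Nc2ccccc2)[C@H]2CC[C@@H]1O2` is yet to be measured. It differs from compound 1 by hydrogen in place of ethyl on an aromatic carbon. For the measured compounds named here, no comparable step is available among the measured pairs, and the shared core appears to carry the result here, so no step beyond the scatter is expected in either direction. The step from compound 1 to compound 3, no change at the digits printed from compound 1 to compound 3 (within the scatter), is estimated to be small. Compound 3 is expected to give about 10000 nM, within a range of 4000 nM to 25000 nM.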

Compound 3, concentration for 50% growth inhibition: 10000 nM
For compound 3 middle estimate and measured number coincide at the digits printed, within the range that was stated.
By their numbers in this assay, from the lowest: compounds 1, 2 and 3 (each within the scatter of the next).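

Replacing ethyl with hydrogen on this aromatic carbon, ortho to a large group, gives no change at the digits printed from compound 1 to compound 3 (within the scatter) in this assay and is the only single-place step shown. At this place, then, the ethyl group is not required for the reading that compound 1 gives. No measurement available accounts for the unchanged reading.

On these data alone, whether an amine, a methoxy group or a longer chain on this carbon would give a different number stays open.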